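A limit compound and its amino-methoxy counterpart

The compounds below may be only part of what the source reports. "The series", "measured", "known", "first", "only" and "open" are said of these compounds alone.

Compound 1 `COc1ccc(-c2c[nH]c(=O)n2-c2cc(OC)c(OC)c(OC)c2)cc1`: > 50000 nM
Compound 2 `COc1cc(-n2c(-c3ccc([N+](=O)[O-])cc3)cn(C(C)=O)c2=O)cc(OC)c1OC`: > 50000 nM

Both results come from a functional assay on ECa-109 cells (Homo sapiens) for cytotoxicity, read by MTT assay, with a stated time of 48 h (on this read-out lower numbers stand for stronger inhibition and higher numbers for weaker inhibition), and neither is a true number. Compound 2 is reported only as a limit, > 50000 nM. It therefore stands at the limit of > 50000 nM in this assay, at which 2 of the 2 values shown sit, which gives no ranking against compound 1.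

Compound 3 `COc1ccc(-c2cn(C(C)=O)c(=O)n2-c2cc(OC)c(OC)c(OC)c2)cc1N` carries 3-amino-4-methoxyphenyl in place of 4-nitrophenyl on an aromatic carbon. Among the compounds with values here, no measured pair shows what such a change does in this assay, so the expectation is loose, and another limit would be no surprise. Any measurable number would mean stronger inhibition, and the expected change is an at least 4.1-fold lower number from compound 2 to compound 3 (0.61 log units; beyond the scatter). For compound 3 the estimated value is 12000 nM, with an expected range from 1000 nM to 50000 nM.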

Compound 3, half-maximal inhibitory concentration: > 50000 nM
Compound 3: no number, only a limit (the forecaster's own chance of this, stated with the estimate: 45%); middle value at least 4.1-fold (0.61 log units) from the limit.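

In this assay compound 3 gives > 50000 nM as a limit and not a number. Compound 2 also stands only at a limit, so no step can be read between compound 2 and compound 3. The compounds shown leave open whether 3-amino-4-methoxyphenyl in place of 4-nitrophenyl changes inhibition at all.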